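From Morpholine to Propylpiperidine on the Sulfonyl Group

A few compounds are considered here, and "the series" means these few. Any claim that something is new, unique, unknown or untested is made for them only; others in the source may bear on it.

The compounds here share one core, seen in compound 1 `CC(C)N1CCN(S(=O)(=O)CCCN2CCC(CNC(=O)c3cccc4c3OCCO4)CC2)CC1` and compound 2 `O=C(NCC1CCN(CCCS(=O)(=O)N2CCOCC2)CC1)c1cccc2c1OCCO2`; they differ only in the ring attached to the sulfonyl sulfur. In an assay on isolated protein for inhibition of 5-hydroxytryptamine receptor 4 (Homo sapiens) (on this read-out lower numbers stand for stronger inhibition and higher numbers for weaker inhibition), compound 1 gives 0.0316 nM, while compound 2 gives 0.398 nM. Among the measured compounds shown here, of the two numbers in hand, compound 2 stands at the higher one, so it is the weaker inhibitor, and the only step measured so far, a 13-fold higher number from compound 1 to compound 2 (1.10 log units; beyond the scatter), shows how much was lost when the carbon-rich ring gave way to morpholin-4-yl.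

Compound 3 `CCCC1CCN(S(=O)(=O)CCCN2CCC(CNC(=O)c3cccc4c3OCCO4)CC2)CC1` goes the other way: 4-propylpiperidin-1-yl in place of morpholin-4-yl on a sulfonyl sulfur. For the measured compounds named here, the step from compound 1 to compound 2 is the one comparison that bears on this change, and it was large. Since the new ring, like that of compound 1, is again a carbon-rich six-membered ring without a hydrogen-bond acceptor, a clear drop in the number is expected, estimated as a 5.0-fold lower number from compound 2 to compound 3 (0.70 log units; beyond the scatter) in this assay. Compound 3 is therefore expected to reach about 0.08 nM, within a range from 0.02 nM to 0.3 nM.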

Compound 3, inhibition constant: 0.0631 nM
Beside the measured number, compound 3's estimate is 1.3-fold (0.10 log units) above it; the range from low to high includes it.
By their numbers in this assay, from the lowest: compounds 1 and 3 (each within the scatter of the next); then compound 2.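

Among the compounds shown here, the loss seen with morpholin-4-yl on the sulfonyl sulfur can be won back by a ring other than the one in compound 1: 4-propylpiperidin-1-yl gives a 6.3-fold lower number from compound 2 to compound 3 (0.80 log units; beyond the scatter) in this assay and thereby returns to the level of compound 1. The comparison with compound 1 shows a 2.0-fold higher number from compound 1 to compound 3 (0.30 log units; within the scatter) in the same read-out, so 4-propylpiperidin-1-yl, with 1 hetero atom in its ring, and 4-isopropylpiperazin-1-yl cannot be told apart here, and morpholin-4-yl is the ring that stands apart among the three. Nothing available here accounts for this difference between the rings.

The step from compound 2 to compound 3 removes the ring oxygen and adds the propyl chain at once, so the two changes cannot be separated. A plain piperidin-1-yl with no chain, or a 4-hydroxypiperidin-1-yl that keeps the oxygen on a piperidine ring, would be needed to show which of the two changes carries the gain.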